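The source may hold more compounds than are shown below. What is called first, only, known or untested is meant among the compounds shown, and "the series" means these compounds.

Compound 1, `COCCCCCCCCCCCCCCC/C=C1/CC(CO)(COC(=O)C(C)(C)C)OC1=O`, and compound 2, `COC(=O)CCCCCCCCCCCCCC/C=C1\CC(CO)(COC(=O)C(C)(C)C)OC1=O`, share the same core and differ only at the far end of their long chain. In a functional assay on K562 cells (Homo sapiens) for antiproliferative activity (on this read-out higher numbers stand for weaker inhibition of growth and lower numbers for stronger inhibition of growth), compound 1 gives 0.138 ug/mL, while compound 2 gives 0.856 ug/mL. Of these two numbers compound 2 has the higher one, and its gap to compound 1 lies beyond the usual scatter of repeated measurements, so compound 2 is the weaker growth inhibitor of the pair.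

Compound 3, `CC(=O)NCCCCCCCCCCCCCCC/C=C1\CC(CO)(COC(=O)C(C)(C)C)OC1=O`, has not yet been tested. It differs from compound 2 in a single place: acetamidomethyl in place of methoxycarbonyl on a saturated chain carbon, ten or more bonds along the chain from a double-bonded chain carbon. Within the data shown here, no measured pair shows this exact change, so its effect is unknown. Compound 3 is therefore expected to stay close to its parent, with an estimated step of a 1.1-fold lower number from compound 2 to compound 3 (0.03 log units; within the scatter) that should not exceed the scatter in either direction. The estimate for compound 3 in this assay is 0.8 ug/mL, within a range from 0.3 ug/mL to 2.5 ug/mL.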

Compound 3, concentration for 50% growth inhibition: 3.38 ug/mL
Beside the measured number, compound 3's estimate is 4.2-fold (0.63 log units) below it, outside the stated range (above it).
By their numbers in this assay, from the lowest: compound 1; then compound 2; then compound 3.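

In this assay, the swap of methoxycarbonyl for acetamidomethyl gives a 3.9-fold higher number from compound 2 to compound 3 (0.60 log units; beyond the scatter) and so makes compound 3 the weaker growth inhibitor of the two. Among these compounds, this is the only measured step here in which just one place changes, and it shows that the far end of the chain is not a silent position: a change on a saturated chain carbon there still moves the read-out beyond the scatter. Nothing measured here explains this step.

The compounds shown leave open which part of the acetamidomethyl group matters, since the swap replaces the whole end of the chain at once. A carboxylic acid or a primary amine at the same chain end would test how much depends on the group there.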